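Dimethylamino for Diethylamino on the Carbonyl Carbon

This account rests on a few compounds, and the source may have more. Where it says the series, first, only, none or still open, it means among the compounds named here.

Compound 1, `CN(C)C(=O)c1ccc(-c2cc(C3=CC(=O)C=CC3=O)no2)s1`, gives 7200 nM in a functional assay on PC-3 cells (Homo sapiens) for cytotoxicity, read by XTT assay, with a stated time of 72 h; on this read-out lower numbers stand for stronger inhibition and higher numbers for weaker inhibition.
Compound 3, `CCN(CC)C(=O)c1ccc(-c2cc(C3=CC(=O)C=CC3=O)no2)s1`, gives 8900 nM in this assay.
Compound 2, `CCN(CC)C(=O)c1ccc(-c2cc(-c3cc(OC)ccc3OC)no2)s1`, reaches only the assay limit > 30000 nM in this assay.

The difference between the core of compound 2 and the core of compound 3 is not broken down here. Within the core of compound 3, the change dimethylamino in place of diethylamino on a carbonyl carbon gave a 1.2-fold lower number from compound 3 to compound 1 (0.09 log units; within the scatter). Compound 4, `COc1ccc(OC)c(-c2cc(-c3ccc(C(=O)N(C)C)s3)on2)c1`, carries the same change on the core of compound 2: dimethylamino in place of diethylamino on a carbonyl carbon, with the place described in the same words. The step from compound 2 to compound 4 is expected to be small, a step that the limit leaves unreadable from compound 2 to compound 4, resting on the earlier step of a 1.2-fold lower number from compound 3 to compound 1 (0.09 log units; within the scatter). This rests also on compound 2 sitting at the limit (the limit of > 30000 nM in this assay, at which 1 of the 3 values shown sits), so compound 4 is expected to be reported as a limit again. Compound 4 is estimated at 40000 nM, between 20000 nM and 100000 nM.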

Compound 4, half-maximal inhibitory concentration: > 30000 nM
Compound 4: only a limit was reported (the forecaster's own chance of this, stated with the estimate: 75%); the middle value lies beyond the limit too.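

Compound 2 and compound 4 both stand only as limits, so no new step can be read between them: the limit of > 30000 nM in this assay, at which 2 of the 4 values shown sit.

The compounds shown leave open whether dimethylamino in place of diethylamino on a carbonyl carbon changes anything on the core of compound 2.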